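The source may hold more compounds than are shown below. What is called first, only, known or untested is meant among the compounds shown, and "the series" means these compounds.

Of the compounds shown here, three that share one core have been tested in an assay on CHO-K1 cells for activation of DNA damage-inducible transcript 3 protein (Homo sapiens), read by a luciferase reporter; on this read-out higher numbers stand for an effect only at larger amounts of compound and lower numbers for an effect already at smaller amounts. Compound 1 `O=C(Nc1ccc(S(=O)(=O)N2CCNCC2)cc1)c1ccc([N+](=O)[O-])o1` gives 26400 nM. Compound 2 `O=C(Nc1ccc(S(=O)(=O)N2CCC(O)CC2)cc1)c1ccc([N+](=O)[O-])o1` gives 2000 nM, and compound 3 `CC1(C)CCN(S(=O)(=O)c2ccc(NC(=O)c3ccc([N+](=O)[O-])o3)cc2)CC1` gives 600 nM. Compound 3 therefore stands at the lowest number of the three: the step of a 3.3-fold lower number from compound 2 to compound 3 (0.52 log units; beyond the scatter) is modest, while the step of a 44-fold lower number from compound 1 to compound 3 (1.64 log units; beyond the scatter) is large, and a 13-fold lower number from compound 1 to compound 2 (1.12 log units; beyond the scatter) shows that the first part of that path already went a long way.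

The next compound, compound 4 `O=C(Nc1ccc(S(=O)(=O)C2CCCCC2)cc1)c1ccc([N+](=O)[O-])o1`, differs from compound 3 in one place: cyclohexyl in place of 4,4-dimethylpiperidin-1-yl on a sulfonyl sulfur. Among the measured compounds shown here, no measured pair changes the group on the sulfonyl sulfur in quite this way, since every step so far swaps one six-membered ring holding a nitrogen for another such ring. Those steps run in one direction, from piperazin-1-yl through 4-hydroxypiperidin-1-yl to 4,4-dimethylpiperidin-1-yl, each giving a lower number, but none removes the ring nitrogen itself, so they offer only loose guidance. For compound 4, the step is expected to be a 1.5-fold higher number from compound 3 to compound 4 (0.18 log units; within the scatter), small enough that it could fall within the scatter in either direction. Compound 4 is therefore estimated at 900 nM, with a range from 250 nM to 3500 nM.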

Compound 4, concentration for half-maximal activity: 700 nM
Estimate against measurement, compound 4: 1.3-fold (0.11 log units) above, within the range that was stated.
By their numbers in this assay, from the lowest: compounds 3 and 4 (each within the scatter of the next); then compound 2; then compound 1.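

In this assay the change to cyclohexyl gives a 1.2-fold higher number from compound 3 to compound 4 (0.07 log units; within the scatter) even though the ring on the sulfonyl sulfur loses its nitrogen and both methyl groups, going from 8 heavy atoms to 6. Among the compounds shown here, this is the first sign that, in this pair, a ring nitrogen on the sulfonyl sulfur is not needed to reach a number at this level, since every earlier ring held one. The carbon-only ring also stands well clear of the other two compounds, with a 2.9-fold lower number from compound 2 to compound 4 (0.46 log units; beyond the scatter) and, much larger, a 38-fold lower number from compound 1 to compound 4 (1.58 log units; beyond the scatter) as its steps, so compounds 3 and 4, whose rings carry neither a hydroxyl nor a second ring nitrogen, share the low end of these four.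

The data shown give no explanation for any of these steps. Still open, from the compounds shown here alone, is how the number would respond to an open-chain group such as hexyl, a smaller ring such as cyclopentyl, a flat phenyl ring, or a cyclohexyl carrying an amine or a carboxylic acid on this sulfonyl sulfur.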